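Chain on the aromatic nitrogen: compound 1 to compound 4

This account rests on a few compounds, and the source may have more. Where it says the series, first, only, none or still open, it means among the compounds named here.

Measured so far:
compound 1 `CCC(CC)Cn1c(Cc2cc(OC)c(OC)c(OC)c2)nc2c(N)ncnc21` — 158000 nM
compound 2 `CC#CCCn1c(Cc2cc(OC)c(OC)c(OC)c2)nc2c(N)nc(F)nc21` — 37200 nM
compound 3 `COc1cc(Cc2nc3c(N)nc(F)nc3n2CCOC(C)C)c(Cl)c(OC)c1OC` — 5370 nM

In a functional assay on MCF7 cells (Homo sapiens) for antiproliferative activity (a higher number here means a weaker inhibitor, a lower number a stronger inhibitor), compound 1 gives 158000 nM, the highest number of the three. Compound 2 and compound 3 both lie below it by more than the scatter, compound 3 furthest. Among the compounds with values here, each of those two differs from compound 1 in more than one place, so no single-change step between measured compounds is available, and the contribution of the chain on the aromatic nitrogen cannot be separated from the other changes in compound 2 or compound 3.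

Compound 4 `C=CCCn1c(Cc2cc(OC)c(OC)c(OC)c2)nc2c(N)ncnc21` is the unmeasured member. It differs from compound 1 in one place: allyl in place of pentan-3-yl on a saturated chain carbon bound to an aromatic nitrogen. Cut one bond further out, the same difference reads 2-ethylbutyl to but-3-en-1-yl.

Compound 2 carries a short unsaturated chain together with a further change on the core, so its lower number offers only a loose hint. For compound 4 the expected step is a 2.3-fold lower number from compound 1 to compound 4 (0.35 log units; beyond the scatter), a modest lowering of the number that may not clear the scatter. Compound 4 is estimated at 70000 nM, with a range from 20000 nM to 200000 nM.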

Compound 4, half-maximal inhibitory concentration: 40700 nM
Compound 4: middle estimate off by 1.7-fold (0.24 log units), on the high side; measured number inside the range.
By their numbers in this assay, from the lowest: compound 3; then compounds 2 and 4 (each within the scatter of the next); then compound 1.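

In this assay, the series now has its first step with a single change: on the core of compound 1, allyl in place of pentan-3-yl gives a 3.9-fold lower number from compound 1 to compound 4 (0.59 log units; beyond the scatter), so the chain on the aromatic nitrogen alone moves the number beyond the scatter, which compound 2 and compound 3 could not show with their further changes. This step changes the branching, the carbon count and the unsaturation of the chain together, as 2-ethylbutyl gives way to but-3-en-1-yl, and it cannot be assigned to any one of these. No measured evidence bears on the origin of this step.

The compounds shown leave open whether a saturated butyl chain on the same core would match compound 4, a comparison that would separate the double bond from the loss of branching and carbon count. Also open, from the compounds shown here alone, are whether the same chain change carries over to the fluorine-bearing core of compound 2, and how a chain carrying an amine or a carboxylic acid would read in this assay.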